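Swapping a benzylamino linker for phenoxy on the shared core

A few compounds are considered here, and "the series" means these few. Any claim that something is new, unique, unknown or untested is made for them only; others in the source may bear on it.

Within the data shown here, in a functional assay on EKVX cells (Homo sapiens) for inhibition, read by sulforhodamine B assay, with a stated time of 48 h (a higher number here means that more compound is tolerated, a lower number that less compound is tolerated), compound 3 `Nc1cc(N)c2nc(-c3ccccc3)c(NCc3ccc(F)cc3)nc2c1` gives 8710 nM, the lowest of the two numbers known here. Compound 1 `Nc1cc(N)c2nc(-c3ccccc3)c(Oc3ccc(Cl)c(Cl)c3)nc2c1` gives 41700 nM in this assay, and the step of a 4.8-fold lower number from compound 1 to compound 3 (0.68 log units; beyond the scatter) exchanges 3,4-dichlorophenoxy for (4-fluorobenzyl)amino. For compound 2 `COc1ccc(CNc2nc3cc(N)cc(N)c3nc2-c2ccccc2)cc1OC` the value < 100000 nM is only a limit of this assay (the limit of < 100000 nM in this assay, at which 1 of the 3 values shown sits). Accordingly there is a step that the limit leaves unreadable from compound 2 to compound 3. Compound 4 `Nc1cc(N)c2nc(-c3ccccc3)c(Oc3ccc(F)cc3)nc2c1` differs from compound 3 by 4-fluorophenoxy in place of (4-fluorobenzyl)amino on an aromatic carbon. This change undoes the linker part of the step from compound 1 while both groups keep a fluorine, so a modest rise toward the number of compound 1 is expected, a 2.3-fold higher number from compound 3 to compound 4 (0.36 log units; beyond the scatter). Compound 4 is therefore estimated at 20000 nM, within a range from 6000 nM to 60000 nM.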

Compound 4, concentration lethal to 50% of the cells: 77600 nM
For compound 4 the middle estimate is 3.9-fold (0.59 log units) below the measured one, and the stated range ends below it.
By their numbers in this assay, from the lowest: compound 3; then compounds 1 and 4 (each within the scatter of the next).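

Replacing (4-fluorobenzyl)amino with 4-fluorophenoxy at this position gives an 8.9-fold higher number from compound 3 to compound 4 (0.95 log units; beyond the scatter) in this assay and keeps a fluorine on the outer ring, so the linking atoms matter here. Among the phenoxy compounds, the ring change gives a 1.9-fold higher number from compound 1 to compound 4 (0.27 log units; within the scatter) and so does not separate them. Nothing shown here gives a reason for the linker's effect.

On these data alone, whether that effect follows the nitrogen or the saturated chain carbon remains open. A benzyloxy or a phenylamino group at this position would separate the two.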